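The compounds below may be only part of what the source reports. "The series", "measured", "known", "first", "only" and "open" are said of these compounds alone.

Two compounds have numbers in an assay on CHO cells for displacement of a labelled ligand from prostaglandin D2 receptor (Mus musculus), read by scintillation counting, with a stated time of 60 min (a higher number here means a weaker inhibitor, a lower number a stronger inhibitor), so far. Compound 1 `CN1C[C@@H](COc2ccc(C(=O)Nc3cccc(CC(=O)O)c3)c(Cl)c2)Oc2ccccc21` gives 16 nM in this assay. Compound 2 `Cc1cc(OC[C@@H]2CN(C)c3ccccc3O2)ccc1C(=O)Nc1cc(CC(=O)O)ccc1Cl` gives 7.7 nM in this assay, the lower of the two numbers, and its gap to compound 1 lies beyond the scatter. Compound 3 `Cc1cc(OC[C@@H]2CN(C)c3ccccc3O2)ccc1C(=O)Nc1ccc(F)c(CC(=O)O)c1` has not been measured. It differs from compound 2 in one place: 3-(carboxymethyl)-4-fluorophenyl in place of 5-(carboxymethyl)-2-chlorophenyl on an amide-type nitrogen. For the measured compounds named here, no measured pair shows this change, so its size is open. Moving the carboxymethyl and exchanging the halogen together is expected to move the number from compound 2 to compound 3 by a 3.2-fold higher number from compound 2 to compound 3 (0.51 log units; beyond the scatter), toward a weaker inhibitor. For compound 3 the estimate in this assay is 25 nM, within 6 nM to 100 nM.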

Compound 3, inhibition constant: 15 nM
Estimate against measurement, compound 3: 1.7-fold (0.22 log units) above; the range from low to high includes it.
By their numbers in this assay, from the lowest: compounds 2, 3 and 1 (each within the scatter of the next, the first and the last beyond it).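

In this assay, 3-(carboxymethyl)-4-fluorophenyl in place of 5-(carboxymethyl)-2-chlorophenyl on the amide-type nitrogen gives a 1.9-fold higher number from compound 2 to compound 3 (0.29 log units; within the scatter) and so leaves the number within the scatter on this shared core. The halogen and the carboxymethyl change together here, and this single step cannot separate the two. Nothing measured here gives a reason for the size of this step. Still open, on these data alone, is how the number responds to hydrogen in place of the fluorine on this ring, or to a carboxyethyl chain in place of the carboxymethyl.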